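Aryl change on the core of compound 1

A few compounds are considered here, and "the series" means these few. Any claim that something is new, unique, unknown or untested is made for them only; others in the source may bear on it.

Within the data shown here, in an assay on CHO cells for inhibition of Glucagon receptor (Homo sapiens), tested at 20 uM (on this read-out lower numbers stand for less inhibition and higher numbers for more inhibition at the one concentration tested (going by the name of the read-out)), compound 1 `CCCCCc1c(C(C)C)nc(C(C)C)c(CO)c1-c1ccccc1CO` gives 44%, the highest of the three numbers measured so far. Compound 2 `CCC/C=C/c1c(C(C)C)nc(C(C)C)c(CO)c1-c1ccc(Cl)c(Cl)c1` gives 39% in this assay, a number within the scatter of that of compound 1, so the two cannot be ordered. Compound 3 `CCCCCc1c(C(C)C)nc(C(C)C)c(CO)c1-c1ccc2ccccc2c1` gives 16% in this assay, a number that lies beyond the scatter below compound 1. Compound 4 `CCCCCc1c(C(C)C)nc(C(C)C)c(CO)c1-c1ccc(Cl)cc1Cl` has not been measured. Its difference from compound 1 is 2,4-dichlorophenyl in place of 2-(hydroxymethyl)phenyl on an aromatic carbon. Among the measured compounds shown here, no step between measured compounds isolates this change. The step from compound 1 to compound 4 is expected to be small and downward, within the scatter, as a number 6 percentage points lower from compound 1 to compound 4 (within the scatter). Compound 4 is therefore estimated at 38%, with a range from 20% to 55%.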

Compound 4, a percentage reported as inhibition, at one concentration (the size of the read-out at that concentration, not a potency): 8%
Estimate against measurement, compound 4: 30 percentage points above, and the stated range ends above it.
By their numbers in this assay, from the lowest: compounds 4 and 3 (each within the scatter of the next); then compounds 2 and 1 (each within the scatter of the next).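

In this assay the aryl group on the aromatic carbon opposite the ring nitrogen proves decisive: 2,4-dichlorophenyl in place of 2-(hydroxymethyl)phenyl gives a number 36 percentage points lower from compound 1 to compound 4 (beyond the scatter), a large step with the heavy-atom count unchanged. The leaving group has 1 hydrogen-bond donor and 1 hydrogen-bond acceptor and the entering group has 0 of each, but this single exchange cannot separate that difference from the arrival of the chlorines. Nothing available accounts for the step.

Still open, as far as these compounds go, is whether an aminomethyl group or a carboxylic acid on that phenyl ring, in place of the hydroxymethyl group, would keep the number of compound 1 at 44%.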